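This account rests on a few compounds, and the source may have more. Where it says the series, first, only, none or still open, it means among the compounds named here.

Working notes on the series.

Compound 1 `NS(=O)(=O)N1CCC(C(=O)/C(=N/O)Nc2ccc(F)c(Br)c2)CC1` is the reference point. In an assay for inhibition of Indoleamine 2,3-dioxygenase 1 (Homo sapiens), with a stated time of 1 h (on this read-out lower numbers stand for stronger inhibition and higher numbers for weaker inhibition), compound 1 gives 63 nM, the lowest of the three numbers recorded so far. The nearest neighbour on this read-out is compound 2 `O=C(NC[C@H]1CC[C@H](C(=O)/C(=N/O)Nc2ccc(F)c(Br)c2)CC1)c1ccccc1`, which in this assay gives 80 nM; the gap between compound 1 and compound 2 lies within the usual scatter, so the two are not separated. The furthest is compound 3 `O/N=C(/CC1CCCCC1)Nc1ccc(F)c(Br)c1`, which in this assay gives 497 nM; here the gap to compound 1 lies beyond the scatter, and compound 3 carries the higher number.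

The next compound, compound 4 `O=C(/C(=N/O)Nc1ccc(F)c(Br)c1)C1CCN(S(=O)(=O)Nc2ccccc2)CC1`, differs from compound 1 in one place: phenyl in place of hydrogen on a sulfonamide nitrogen. For the measured compounds named here, no step between measured compounds isolates this change, so any expectation rests on the compounds above alone. Compound 2, which carries a large aromatic appendage on the same side of the core, gives a value within the scatter of compound 1, and this is the only hint available. On that basis the step from compound 1 to compound 4 is expected to be small, a 1.2-fold higher number from compound 1 to compound 4 (0.08 log units; within the scatter), with no direction claimed beyond the scatter. Compound 4 is accordingly estimated at 75 nM in this assay, with a range from 25 nM to 220 nM.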

Compound 4, half-maximal inhibitory concentration: 98 nM
Compound 4: the middle estimate sits 1.3-fold (0.12 log units) below what was measured; the measured number falls inside the stated range.
By their numbers in this assay, from the lowest: compounds 1, 2 and 4 (each within the scatter of the next); then compound 3.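

In this assay, placing phenyl instead of hydrogen on the sulfonamide nitrogen gives a 1.6-fold higher number from compound 1 to compound 4 (0.19 log units; within the scatter), so the two compounds are not separated. For the compounds shown here, this is the first direct reading at this position: within this pair, one hydrogen on that nitrogen can be replaced, and a six-membered aromatic ring of carbon only is accepted there without a change beyond the scatter. Nothing at hand bears on why this step is small.

Still open, on these data alone, is whether a methyl, a carboxylic acid or a short chain ending in an amine on the same nitrogen would also stay within the scatter of compound 1, and whether the second hydrogen on that nitrogen can be replaced as well. Also open, as far as these compounds go, is whether a fluorine or a methoxy group on the phenyl of compound 4 would move the number beyond the scatter in either direction, since a single aromatic example cannot show how far this tolerance extends.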